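Chloro for methyl on an amide that has shown nothing

The source may report more compounds than this note shows. Statements on the series, on what has been measured and on what is new or still open speak of the compounds shown alone.

Three amides built on one shared core have been tested in a functional assay on HeLa cells (Homo sapiens) for antiproliferative activity, read by MTT assay, with a stated time of 72 h; on this read-out lower numbers stand for stronger inhibition and higher numbers for weaker inhibition. Compound 1 `O=C(Nc1ccc(Cl)c(-c2nnc3c(Cl)cccn23)c1)c1ccc(F)cc1Cl` carries a 2-chloro-4-fluorophenyl group on its carbonyl carbon. In this assay compound 1 is known only as a limit of > 100000 nM and gives no number. Compound 2 `CS(=O)(=O)c1ccc(C(=O)Nc2ccc(Cl)c(-c3nnc4c(Cl)cccn34)c2)cc1` bears a 4-(methylsulfonyl)phenyl group in the same place. In this assay compound 2 likewise stops at a limit of > 100000 nM. Compound 3 `Cc1cc(Cl)ccc1C(=O)Nc1ccc(Cl)c(-c2nnc3c(Cl)cccn23)c1` carries a 4-chloro-2-methylphenyl group. In this assay compound 3 too is recorded only as a limit of > 100000 nM. The steps a step that the two limits leave unreadable from compound 1 to compound 2, a step that the two limits leave unreadable from compound 1 to compound 3 and a step that the two limits leave unreadable from compound 2 to compound 3 therefore cannot be sized, since every value sits at the limit of > 100000 nM in this assay, at which 3 of the 3 values shown sit, and compound 3 stands at the same limit as its two companions with no order among them.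

The next compound, compound 4 `O=C(Nc1ccc(Cl)c(-c2nnc3c(Cl)cccn23)c1)c1ccc(Cl)cc1Cl`, differs from compound 3 by chloro in place of methyl on an aromatic carbon. Going by the values given here, none of the measured steps can be read, so they give no direction for this change; they show only that three different aryl groups on the carbonyl carbon left the shared core without readable activity. Compound 4 is therefore expected to remain at the limit as well, so that the estimated step of a number no higher from compound 3 to compound 4 (the limit leaves the size open) means no readable movement. The estimate for compound 4 in this assay is 100000 nM, with a range from 30000 nM to 300000 nM.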

Compound 4, half-maximal inhibitory concentration: > 100000 nM
Compound 4: no number, only a limit; the forecaster's own chance of this, stated with the estimate: 85%; the middle value sits exactly at the limit.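

In this assay compound 4 gives > 100000 nM, which is a limit and not a number. Its steps from compound 1, compound 2 and compound 3 therefore cannot be read: the limit of > 100000 nM in this assay, at which 4 of the 4 values shown sit.

The compounds shown leave open whether any group on the carbonyl carbon of the shared core gives a readable value in this assay.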